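This account rests on a few compounds, and the source may have more. Where it says the series, first, only, none or still open, it means among the compounds named here.

Measured so far:
- compound 1, `COc1cc(/C=C/C(=O)C2=C(/C=C/c3ccc(O)c(OC)c3)NC(=O)NC2c2ccc(C)cc2)ccc1O`: 36.3%
- compound 2, `COc1cc(/C=C/C(=O)C2=C(/C=C/c3ccc(O)c(OC)c3)NC(=O)NC2c2ccccc2O)ccc1O`: 80.9%
- compound 3, `COc1cc(/C=C/C(=O)C2=C(/C=C/c3ccc(O)c(OC)c3)NC(=S)NC2c2ccc(C)cc2)ccc1O`: 30%

All three numbers come from a functional assay, with a stated time of 20 min, tested at 20 uM (a higher number here means a stronger effect of the compound at the concentration tested, a lower number a weaker effect), and in this assay compound 2 gives the highest value of the three; compound 3 gives the lowest, though its gap to compound 1 is within the scatter.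

Within the data shown here, the one counted step is a number 44.6 percentage points higher from compound 1 to compound 2 (beyond the scatter), and the change behind it is 2-hydroxyphenyl in place of 4-methylphenyl on a saturated ring carbon. Compound 3 carries a different core from compound 1; the difference between the two cores is not broken down here.

Compound 4, `COc1cc(/C=C/C(=O)C2=C(/C=C/c3ccc(O)c(OC)c3)NC(=S)NC2c2ccccc2O)ccc1O`, is not yet measured. Among the measured compounds shown here, it differs from compound 3 by 2-hydroxyphenyl in place of 4-methylphenyl on a saturated ring carbon — the same change as the one from compound 1 to compound 2, made at the same place on the saturated ring carbon.

For compound 4 the expected step is a number 42 percentage points higher from compound 3 to compound 4 (beyond the scatter), which rests on the measured step of a number 44.6 percentage points higher from compound 1 to compound 2 (beyond the scatter) on the other core, with some allowance because compound 3 starts from 30% and the change has been seen only once. Compound 4 is therefore estimated at 72% in this assay, expected between 50% and 90%.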

Compound 4, a percentage reported as activity, at one concentration (the size of the read-out at that concentration, not a potency): 79.9%
Compound 4: middle estimate off by 7.9 percentage points, on the low side; low and high end bracket the measured number.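

In this assay, 2-hydroxyphenyl in place of 4-methylphenyl on the saturated ring carbon gives a number 49.9 percentage points higher from compound 3 to compound 4 (beyond the scatter). Set beside the same change on the core of compound 1, the step carries over between the two cores with no difference that can be told apart: the same change on two cores in this assay, a number 44.6 percentage points higher (beyond the scatter) from compound 1 to compound 2 and a number 49.9 percentage points higher (beyond the scatter) from compound 3 to compound 4, 5.3 percentage points apart, within the scatter of two such steps

This rests on a single pair of groups on just two cores, read at one tested concentration, so it supports carrying this one change between these two cores only, gives no potency, and does not explain why the read-out moves.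

The compounds shown hold only 2-hydroxyphenyl and 4-methylphenyl on the saturated ring carbon, so it remains open whether an unsubstituted phenyl, a 4-hydroxyphenyl or a 2-methoxyphenyl there would give a step of similar size on either core. Also open, from the compounds shown here alone, is how a carboxylic acid or an amine in place of the 2-(4-hydroxy-3-methoxyphenyl)ethenyl group would affect the read-out.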